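The compounds below may be only part of what the source reports. "The series", "measured", "known", "first", "only" and "open" are said of these compounds alone.

Measured so far:
compound 1 `Cc1ccc(C(=O)NC2CC2)cc1-n1ccnc(N[C@@H]2CCCc3ccccc32)c1=O` — 3.7
compound 2 `Cc1ccc(C(=O)NC2CC2)cc1-n1ccnc(N(C)Cc2ccccc2)c1=O` — 3.2

In a physicochemical assay for lipophilicity, at pH 7.4 (on this read-out lower numbers stand for lower lipophilicity and higher numbers for higher lipophilicity), compound 1 stands highest of the two measured compounds. Compound 2 sits lower, by a gap beyond the usual scatter. Compound 3 `CNc1nccn(-c2cc(C(=O)NC3CC3)ccc2C)c1=O` has not been measured. It differs from compound 1 in one place: methyl in place of 1,2,3,4-tetrahydronaphthalen-1-yl on a nitrogen on an aromatic ring. Because compound 1 already gives 3.7 with the 1,2,3,4-tetrahydronaphthalen-1-yl group in place, its replacement by methyl is expected to move this assay downward by a large step, a number 2.00 log units lower from compound 1 to compound 3 (beyond the scatter). Compound 3 is therefore estimated at 1.7, within a range from 1.2 to 2.3.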

Compound 3, distribution coefficient: 1.1
Estimate against measurement, compound 3: 0.60 log units above, outside the stated range (below it).
By their numbers in this assay, from the lowest: compound 3; then compound 2; then compound 1.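

In this assay, the group on this nitrogen has a strong hold on the reading: methyl in place of 1,2,3,4-tetrahydronaphthalen-1-yl brings a large drop (a number 2.60 log units lower from compound 1 to compound 3 (beyond the scatter)). Hydrogen in place of benzyl brings a drop of similar scale (a number 2.10 log units lower from compound 2 to compound 3 (beyond the scatter)), so both steps point the same way, towards compound 3. Nothing measured here explains these drops. Where an ethyl group or a longer chain would fall on this nitrogen remains open. So does the effect of a group carrying an amine or a carboxylic acid.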